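This account rests on a few compounds, and the source may have more. Where it says the series, first, only, none or still open, it means among the compounds named here.

Compound 1 `COCCCCCCCCCCCCCCC/C=C1\CC(CO)(COC(=O)C(C)(C)C)OC1=O` — 4.65 ug/mL
Compound 2 `COCCCCCCCCCCC/C=C1\CC(CO)(COC(=O)C(C)(C)C)OC1=O` — 5.22 ug/mL
Compound 3 `CCCCCCCCC(O)CCCCCC/C=C1\CC(CO)(COC(=O)C(C)(C)C)OC1=O` — > 10 ug/mL

The three measured compounds share one core and differ only in their side chain. In a functional assay on HL-60 cells (Homo sapiens) for antiproliferative activity (on this read-out higher numbers stand for weaker inhibition of growth and lower numbers for stronger inhibition of growth), compound 1 gives 4.65 ug/mL, and compound 2 gives 5.22 ug/mL; the step of a 1.1-fold higher number from compound 1 to compound 2 (0.05 log units; within the scatter). For compound 3 this assay reports only a limit, > 10 ug/mL. Compound 3 therefore stands at the limit of this assay (the limit of > 10 ug/mL in this assay, at which 1 of the 3 values shown sits), with an at least 2.1-fold higher number from compound 1 to compound 3 (0.33 log units; beyond the scatter) and an at least 1.9-fold higher number from compound 2 to compound 3 (0.28 log units; that floor lies within the scatter).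

Compound 4 `CCCCCOCCCCCCC/C=C1\CC(CO)(COC(=O)C(C)(C)C)OC1=O` has not yet been measured. It differs from compound 3 in one place: (pentyloxy)methyl in place of 1-hydroxynonyl on a saturated chain carbon, six bonds along the chain from a double-bonded chain carbon. Both steps that bear on this change, from compound 1 and from compound 2 to compound 3, ran toward weaker inhibition when the 1-hydroxynonyl group entered, and compound 4, like compound 1 and compound 2, carries an ether in the chain. Compound 4 is therefore expected to return to the level of compound 1 and compound 2, an expected step of an at least 1.8-fold lower number from compound 3 to compound 4 (0.25 log units; that floor lies within the scatter). The estimate for compound 4 in this assay is 5.5 ug/mL, with a range from 3 ug/mL to 10 ug/mL.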

Compound 4, concentration for 50% growth inhibition: 2.96 ug/mL
The estimate for compound 4 lay 1.9-fold (0.27 log units) above the measured number; the measured number lies below the stated range.
By their numbers in this assay, from the lowest: compounds 4, 1 and 2 (each within the scatter of the next). At a limit, above all of these: compound 3.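

In this assay, replacing the 1-hydroxynonyl group with (pentyloxy)methyl on a saturated chain carbon, six bonds along the chain from a double-bonded chain carbon, gives an at least 3.3-fold lower number from compound 3 to compound 4 (0.52 log units; beyond the scatter). Compared with the other two ethers, the data show a 1.8-fold lower number from compound 2 to compound 4 (0.25 log units; within the scatter) and a 1.6-fold lower number from compound 1 to compound 4 (0.20 log units; within the scatter), so an ether oxygen at this place on the chain leaves the read-out level with those of compound 1 and compound 2. Compound 3 gives > 10 ug/mL, which is a limit and not a number, so its step to compound 4 is only a floor: the limit of > 10 ug/mL in this assay, at which 1 of the 4 values shown sits.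

The compounds shown do not separate the hydroxyl from the length of the 1-hydroxynonyl group, as these two features change together. On these data alone, how an amine or a carboxylic acid at this place on the chain would read also remains open.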